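This account rests on a few compounds, and the source may have more. Where it says the series, first, only, none or still open, it means among the compounds named here.

In a functional assay on SMMC-7721 cells (Homo sapiens) for antiproliferative activity, read by MTT assay, with a stated time of 48 h (a higher number here means a weaker inhibitor, a lower number a stronger inhibitor), compound 1 `Cn1cc(C2=C(c3nn(CCCN4CCCCC4)c4ncccc34)C(=O)N(c3ccc(Cl)cc3)C2=O)c2ccccc21` gives > 100000 nM, which is a limit and not a number. Compound 2 `CN1CCN(CCCn2nc(C3=C(c4cn(C)c5ccccc45)C(=O)NC3=O)c3cccnc32)CC1` gives > 100000 nM, also a limit. Compound 3 `Cn1cc(C2=C(c3n[nH]c4ncccc34)C(=O)NC2=O)c2ccccc21` gives > 100000 nM, again a limit. Compound 1 therefore has no measured number, only a limit shared with the two other compounds.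

Compound 4 `COc1ccc(N2C(=O)C(c3cn(C)c4ccccc34)=C(c3nn(CCCN4CCCCC4)c4ncccc34)C2=O)cc1` differs from compound 1 in one group: methoxy in place of chloro on an aromatic carbon. In words, methoxy stands in place of chloro on an aromatic carbon, which turns 4-chlorophenyl to 4-methoxyphenyl.

Going by the values given here, only one measured step is available, a step that the two limits leave unreadable from compound 2 to compound 3. It concerns a group on an aromatic nitrogen and has no readable size, so it offers no guide to this change. Because of the limit of > 100000 nM in this assay, at which 3 of the 3 values shown sit, the data show no number from which a real step could be judged. The expected step of a number no higher from compound 1 to compound 4 (the limit leaves the size open) is therefore none beyond the scatter, in either direction. For compound 4 the estimate in this assay is 100000 nM, with an expected range of 30000 nM to 200000 nM, and another limit is the likeliest report.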

Compound 4, half-maximal inhibitory concentration: 1740 nM
Beside the measured number, compound 4's estimate is 57-fold (1.76 log units) above it, and the stated range ends above it.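

In this assay, going by these compounds alone, the change from 4-chlorophenyl to 4-methoxyphenyl gives an at least 57-fold lower number from compound 1 to compound 4 (1.75 log units; beyond the scatter) and is the first step in this set with a readable size. It shows that the group on this aromatic carbon, para to a large group, can by itself carry a compound from a limit to a measured number while the rest of the molecule stays the same. The size of the step is only a lower bound because compound 1 has a limit and not a number: the limit of > 100000 nM in this assay, at which 3 of the 4 values shown sit.

As far as these compounds go, whether a hydroxyl, an ethoxy or an amine at this place would also give a measured number remains open, as does the result for a plain phenyl. Also open, from the compounds shown here alone, is whether methoxy would lower the number in a compound carrying the 3-(4-methylpiperazin-1-yl)propyl chain of compound 2.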